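The source may hold more compounds than are shown below. What is called first, only, known or untested is meant among the compounds shown, and "the series" means these compounds.

Compound 1 `O=C(Nc1ccc(Sc2nc3ccccc3s2)cc1)c1ccccc1O` gives 74000 nM in an ADME assay on HEK293 cells (Homo sapiens) for cytotoxicity, read by reporter gene assay and resazurin assay, with a stated time of 48 h; on this read-out lower numbers stand for higher toxicity in this test and higher numbers for lower toxicity in this test.
Compound 2 `O=C(Nc1ccc(Sc2nc3ccccc3s2)cc1)c1cccc(Br)c1` gives 74000 nM in this assay.
Compound 3 `O=C(Nc1ccc(Sc2nc3ccccc3s2)cc1)c1cc(Br)ccc1O` gives 42000 nM in this assay.

Compound 3 shows the lowest of the three numbers, yet both of its neighbours lie within the scatter: a 1.8-fold lower number from compound 1 to compound 3 (0.25 log units; within the scatter) and a 1.8-fold lower number from compound 2 to compound 3 (0.25 log units; within the scatter). Compound 4 `O=C(Nc1ccc(Sc2nc3ccccc3s2)cc1)c1ccccc1` differs from compound 3 in one place: phenyl in place of 5-bromo-2-hydroxyphenyl on a carbonyl carbon. Going by the values given here, the steps that bear on this are the two that built compound 3 from compound 1 and compound 2, each small and within the scatter, and the move between compound 1 and compound 2 itself gave no change at the digits printed from compound 1 to compound 2 (within the scatter). No step beyond the scatter is therefore expected in this assay; the number for compound 4 is estimated at 65000 nM, between 30000 nM and 140000 nM, which means an expected step of a 1.5-fold higher number from compound 3 to compound 4 (0.19 log units; within the scatter).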

Compound 4, half-maximal cytotoxic concentration: > 100000 nM
Compound 4: no number, only a limit; the forecaster's own chance of this, stated with the estimate: 10%; middle value at least 1.5-fold (0.18 log units) away from the limit.
By their numbers in this assay, from the lowest: compounds 3, 1 and 2 (each within the scatter of the next). At a limit, above all of these: compound 4.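

Taking away both the bromo and the hydroxy group gives the first step beyond the scatter in this assay: an at least 2.3-fold higher number from compound 3 to compound 4 (0.37 log units; beyond the scatter). Compound 4 carries a limit, > 100000 nM, and not a number. Taking away one group alone gives only floors within the scatter, an at least 1.3-fold higher number from compound 2 to compound 4 (0.13 log units; that floor lies within the scatter) and an at least 1.3-fold higher number from compound 1 to compound 4 (0.13 log units; that floor lies within the scatter), so whether either group matters more on its own cannot be read: the same change on two cores in this assay, a 1.8-fold lower number (0.25 log units; within the scatter) from compound 1 to compound 3 and an at least 1.3-fold lower number (0.13 log units; that floor lies within the scatter) from compound 4 to compound 2; the limit leaves it open whether they differ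

From the compounds shown here alone, how far the true value of compound 4 lies past its limit stays open. So does whether an amine or a carboxylic acid on the phenyl of compound 4 would give a lower number.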